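The compounds below may be only part of what the source reports. "The series", "measured", "known", "first", "only" and "open" are said of these compounds alone.

In an assay on HEK293 cells for displacement of a labelled ligand from prostaglandin D2 receptor 2 (Homo sapiens) (on this read-out higher numbers stand for weaker inhibition and lower numbers for stronger inhibition), three closely related compounds have been measured. Compound 1, `O=C(O)Cn1c(SCc2ccccc2Cl)nc2ccccc21`, gives 370 nM. Compound 2, `COC(=O)c1ccccc1CSc1nc2ccccc2n1CC(=O)O`, gives 520 nM. Compound 3, `COc1ccc(Cl)cc1CSc1nc2ccccc2n1CC(=O)O`, gives 740 nM.

Compound 2 arises from compound 1 by one change, (methoxycarbonyl in place of chloro on an aromatic carbon), and this change made a step of a 1.4-fold higher number from compound 1 to compound 2 (0.15 log units; within the scatter). Compound 4, `COC(=O)c1ccc(OC)c(CSc2nc3ccccc3n2CC(=O)O)c1`, has not yet been measured; it arises from compound 3 by methoxycarbonyl in place of chloro on an aromatic carbon. This is the same kind of change, though not the same: in compound 2 the entering group sits ortho to a large group, whereas in compound 4 it sits meta to a large group and para to a methoxy group. The difference between the core of compound 3 and the core of compound 1 is not broken down here.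

Since the earlier change of this kind moved the number only slightly, compound 4 is expected to land close to compound 3, with a step of a 1.4-fold higher number from compound 3 to compound 4 (0.13 log units; within the scatter). The estimate for compound 4 in this assay is therefore 1000 nM, with a likely range from 400 nM to 2500 nM.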

Compound 4, half-maximal inhibitory concentration: 29 nM
Compound 4: the middle estimate sits 34-fold (1.54 log units) above what was measured, and the stated range ends above it.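

Putting methoxycarbonyl in place of chloro gave a step of a 26-fold lower number from compound 3 to compound 4 (1.41 log units; beyond the scatter), so this change does not carry a fixed size from one core to another in this series: the same change on two cores in this assay, a 1.4-fold higher number (0.15 log units; within the scatter) from compound 1 to compound 2 and a 26-fold lower number (1.41 log units; beyond the scatter) from compound 3 to compound 4, 36-fold (1.55 log units) apart, beyond the scatter of two such steps

The two pairs differ in more than one way, since the core differs and, in compound 4, the methoxycarbonyl sits meta to a large group and para to a methoxy group, a placement it does not share with compound 2. For the compounds shown here, with only two pairs, the data show that the outcome of this change cannot be read across these cores, but they do not show which difference between the pairs matters or how the change would behave on any other core.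

The compounds shown leave open whether an amide or a nitrile in the same place on the core of compound 3 would come close to compound 4 at 29 nM. They also leave open whether compound 4 would keep that value with a hydrogen in place of its methoxy group.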